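Aryl selenocyanate carbamates: ester side chain and growth inhibition

The source may hold more compounds than are shown below. What is called first, only, known or untested is meant among the compounds shown, and "the series" means these compounds.

Measured so far:
compound 1 `CC(C)COC(=O)Nc1ccc([Se]C#N)cc1`: 47300 nM
compound 2 `Cc1ccc(OC(=O)Nc2ccc([Se]C#N)cc2)cc1`: 32300 nM
compound 3 `CCOC(=O)Nc1ccc([Se]C#N)cc1`: 39200 nM

All three share the same selenocyanate-bearing core and differ only in the carbamate ester. In a functional assay on PC-3 cells (Homo sapiens) for cytotoxicity, read by MTT assay, with a stated time of 72 h (a higher number here means a weaker inhibitor of growth, a lower number a stronger inhibitor of growth), compound 3 stands between the other two: the gap to compound 1 and the gap to compound 2 are each within the scatter, so the three numbers cannot be ranked.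

The next compound is compound 4 `N#C[Se]c1ccc(NC(=O)Oc2ccccc2)cc1`, to be measured in this assay. It differs from compound 3 in one place: phenyl in place of ethyl on an oxygen next to a carbonyl group.

Among the compounds with values here, only one measured step touches this position, a 1.2-fold lower number from compound 1 to compound 3 (0.08 log units; within the scatter), and it lies within the scatter, so exchanging one saturated chain on the ester oxygen for another left the number unchanged. Compound 2 carries an aromatic ester group and gives 32300 nM, which sits within the scatter of compound 3. Within the data shown here, nothing among the measured compounds points to a move beyond the scatter when an aromatic group replaces the ethyl group.

Compound 4 is therefore expected to give about 35000 nM in this assay, most likely between 15000 nM and 80000 nM, a step of a 1.1-fold lower number from compound 3 to compound 4 (0.05 log units; within the scatter) that is expected to stay within the scatter.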

Compound 4, concentration for total growth inhibition: 37500 nM
Compound 4: middle estimate off by 1.1-fold (0.03 log units), on the low side; low and high end bracket the measured number.
By their numbers in this assay, from the lowest: compounds 2, 4, 3 and 1 (each within the scatter of the next).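

In this assay, within the data shown here, phenyl in place of ethyl on an oxygen next to a carbonyl group stays within the scatter (a 1.0-fold lower number from compound 3 to compound 4 (0.02 log units; within the scatter)), which gives a direct exchange of a saturated chain for an aromatic ring at this position, where the earlier compounds allowed only an indirect reading. Phenyl in place of isobutyl at the same position also stays within the scatter (a 1.3-fold lower number from compound 1 to compound 4 (0.10 log units; within the scatter)), and hydrogen in place of methyl on an aromatic carbon of the ester group does the same (a 1.2-fold higher number from compound 2 to compound 4 (0.06 log units; within the scatter)), so among these compounds neither the ring nor its methyl group separates one number from another. All four compounds therefore remain unranked, and no accompanying data bear on why the exchanges at this position stay within the scatter.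

The compounds shown leave open whether a longer chain on the ester oxygen, or an aromatic ester ring carrying an amine or a carboxylic acid, would move the number beyond the scatter. Also open, as far as these compounds go, is whether any exchange outside the carbamate ester, on the shared core or at the selenocyanate group, would do so.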